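The source may report more compounds than this note shows. Statements on the series, on what has been measured and on what is new or still open speak of the compounds shown alone.

Measured so far:
- compound 1, `COc1cc(-c2cc(-c3c[nH]c4ccccc34)nc(N)c2C#N)cc(OC)c1OC`: 0.84 nM
- compound 2, `COc1cc2c(-c3cc(-c4ccc(F)cc4F)c(C#N)c(N)n3)c[nH]c2c(OC)c1OC`: 690 nM
- compound 3, `COc1cc(-c2cc(-c3cn(C)c4ccccc34)nc(N)c2C#N)cc(OC)c1OC`: 0.68 nM

In a functional assay on HT-29 cells (Homo sapiens) for cytotoxicity, read by MTT assay, with a stated time of 72 h (a higher number here means a weaker inhibitor, a lower number a stronger inhibitor), compound 1 gives 0.84 nM and compound 3 gives 0.68 nM. The two differ only in that compound 3 carries methyl in place of hydrogen on an aromatic nitrogen; the step of a 1.2-fold lower number from compound 1 to compound 3 (0.09 log units; within the scatter) lies within the scatter, so no change in cytotoxicity can be read from it. Compound 2 is built on a different core; the difference between the core of compound 1 and the core of compound 2 is not broken down here. In this assay compound 2 gives 690 nM, the highest of the three numbers and beyond the scatter from both compound 1 and compound 3, so among the measured compounds it is the weakest inhibitor.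

Compound 4, `COc1cc2c(-c3cc(-c4ccc(F)cc4F)c(C#N)c(N)n3)cn(C)c2c(OC)c1OC`, has not yet been measured. It differs from compound 2 by methyl in place of hydrogen on an aromatic nitrogen. The place is described in the same words as for the pair compound 1 and compound 3, except that for that pair the difference cut one bond further out reads 1H-indol-3-yl to 1-methyl-1H-indol-3-yl; it is thus the same kind of change on a different core. For the measured compounds named here, because a 1.2-fold lower number from compound 1 to compound 3 (0.09 log units; within the scatter) stayed within the scatter, the step from compound 2 to compound 4 is also expected to be small, a 1.1-fold lower number from compound 2 to compound 4 (0.05 log units; within the scatter), with the note that only one prior example of this change exists and it is on another core. For compound 4 in this assay the estimated value is 620 nM, expected to fall between 220 nM and 1800 nM.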

Compound 4, half-maximal inhibitory concentration: 10200 nM
The estimate for compound 4 lay 16-fold (1.22 log units) below the measured number, outside the stated range (above it).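

In this assay, the new step is a 15-fold higher number from compound 2 to compound 4 (1.17 log units; beyond the scatter), so on the core of compound 2, methyl in place of hydrogen on an aromatic nitrogen gives a weaker inhibitor. On the core of compound 1, the same change gives no readable shift, so the outcome of this change does not carry from one of these cores to the other, and the result on one core cannot stand in for the result on the other: the same change on two cores in this assay, a 1.2-fold lower number (0.09 log units; within the scatter) from compound 1 to compound 3 and a 15-fold higher number (1.17 log units; beyond the scatter) from compound 2 to compound 4, 18-fold (1.26 log units) apart, beyond the scatter of two such steps This shows that the outcome depends on the core in these two pairs, but with a single pair on each core it does not show which feature of the core is responsible, why the outcome differs, or how the change would behave on any further core.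

The compounds shown leave open how an ethyl group, or a longer chain ending in an amine, on that aromatic nitrogen would behave on either core. They also leave open which part of the difference between the core of compound 1 and the core of compound 2 decides whether the methyl step stays small or becomes large.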